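The compounds below may be only part of what the source reports. "The series", "measured", "known", "first", "only" and "open" are said of these compounds alone.

Compound 3 `CCCCCCCCCCCCCCNC(=O)[C@@H](NC(=O)c1ccccc1)[C@@H](C)O` carries a benzoyl group on the amine nitrogen. In a functional assay on SiHa cells (Homo sapiens) for cytotoxicity, read by MTT assay, with a stated time of 48 h (on this read-out lower numbers stand for stronger inhibition and higher numbers for weaker inhibition), compound 3 gives > 200000 nM, which is a limit of the assay rather than a number (the limit of > 200000 nM in this assay, at which 1 of the 3 values shown sits). Going by the values given here, compound 1 `CCCCCCCCCCCCCCNC(=O)[C@@H](N)[C@@H](C)O`, with hydrogen in that place, gives 11000 nM, and the step of an at least 18-fold higher number from compound 1 to compound 3 (1.25 log units; beyond the scatter) is the only measured step that touches the nitrogen substituent. Among the compounds with values here, compound 4 `CCCCCCCCCCCCCCNC(=O)[C@@H](NC(=O)c1cccs1)[C@@H](C)O` differs from compound 3 by thiophen-2-yl in place of phenyl on a carbonyl carbon; no measured step covers this exchange directly. Compound 2 `CCCCCCCCCCCCNC(=O)[C@@H](NC(=O)c1cccs1)[C@@H](C)O` carries the same thiophene carbonyl on a shorter chain and gives 23900 nM. Because compound 2 gives 23900 nM, compound 4 is expected to give 30000 nM, with a range from 10000 nM to 150000 nM. That amounts to an expected step of an at least 6.6-fold lower number from compound 3 to compound 4 (0.82 log units; beyond the scatter) toward a lower number.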

Compound 4, half-maximal inhibitory concentration: 63000 nM
For compound 4 the middle estimate is 2.1-fold (0.32 log units) below the measured one; low and high end bracket the measured number.
By their numbers in this assay, from the lowest: compound 1; then compound 2; then compound 4. At a limit, above all of these: compound 3.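

Compound 3 stands at a limit of the assay, not at a number: the limit of > 200000 nM in this assay, at which 1 of the 4 values shown sits. Even so, thiophen-2-yl in place of phenyl on the carbonyl carbon gives an at least 3.1-fold lower number from compound 3 to compound 4 (0.50 log units; beyond the scatter), so an acylated nitrogen can still give a measurable number, while (thiophen-2-yl)carbonyl in place of hydrogen on the amine nitrogen still costs a 5.7-fold higher number from compound 1 to compound 4 (0.76 log units; beyond the scatter). With this carbonyl group held constant, the ethyl added to the chain gives a 2.6-fold higher number from compound 2 to compound 4 (0.42 log units; beyond the scatter), so chain length also counts here.

The compounds shown leave open whether furan-2-yl or pyridin-2-yl on the carbonyl carbon would follow thiophen-2-yl.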